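The compounds below may be only part of what the source reports. "The series", "measured", "known", "first", "only" and "open" are said of these compounds alone.

In an ADME assay on TERT-RPE1 cells (Homo sapiens) for cytotoxicity, read by MTT assay, with a stated time of 72 h (on this read-out lower numbers stand for stronger inhibition and higher numbers for weaker inhibition), compound 1 (`COc1ccc(/C=C2/CN(C)/C(=N/c3ccc(Cl)cc3)S2)cc1`) gives 39600 nM. Among the two numbers recorded in this assay, this is the higher one, though the gap to compound 3 is within the scatter. Compound 3 (`FC(F)(F)c1cc(/N=C2/NC/C(=C/c3ccccc3)S2)cc(C(F)(F)F)c1`) gives 32800 nM in this assay, so the two cannot be told apart on this read-out. Compound 2 (`COc1ccc(/C=C2\S/C(=N\c3ccc(Cl)cc3)N(C)C2=O)cc1`) reaches only a limit in this assay, recorded as > 100000 nM; here the limit of > 100000 nM in this assay, at which 1 of the 3 values shown sits, marks the ceiling of the measurement and not a number.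

Compound 4 (`COc1ccc(/C=C2/CN(C)/C(=N/c3ccc(C(F)(F)F)cc3)S2)cc1`) has not yet been measured in this assay. It differs from compound 1 in one place: trifluoromethyl in place of chloro on an aromatic carbon. Among the measured compounds shown here, no pair of measured compounds in this set differs by exactly this change, so no measured step can be borrowed for it. What can be said is that compound 3, which carries trifluoromethyl groups on its aniline ring, gives 32800 nM, a number within the scatter of compound 1, so the presence of trifluoromethyl on this ring has not moved the read-out far in the shown cases.

He therefore expects the step of a 1.0-fold higher number from compound 1 to compound 4 (0.00 log units; within the scatter) to be no larger than the scatter, in either direction. For compound 4 he estimates 40000 nM in this assay, within a range from 15000 nM to 100000 nM.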

Compound 4, half-maximal inhibitory concentration: 72000 nM
The estimate for compound 4 lay 1.8-fold (0.26 log units) below the measured number; the measured number falls inside the stated range.
By their numbers in this assay, from the lowest: compounds 3, 1 and 4 (each within the scatter of the next, the first and the last beyond it). At a limit, above all of these: compound 2.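

In this assay, trifluoromethyl in place of chloro on an aromatic carbon, para to a large group, gives a 1.8-fold higher number from compound 1 to compound 4 (0.26 log units; within the scatter). Among the compounds shown here, this is the first direct reading of this change at this position, since compound 3 differs from compound 1 in more than one place and could only hint at what the exchange would do; on this read-out, the position takes either group without a step that rises beyond the scatter. The pair gives a size for the step but no reason for it, and nothing measured here bears on a cause.

The compounds shown place only chloro and trifluoromethyl at this position on the core of compound 1, so it remains open whether an amine, a carboxylic acid or a longer chain there would also stay within the scatter of compound 1. Going by these compounds, it also remains open whether the same exchange would read alike on the core of compound 2, whose entry in this assay is a limit and not a number.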